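Taking the nonylcarbonyl off compound 1

This account rests on a few compounds, and the source may have more. Where it says the series, first, only, none or still open, it means among the compounds named here.

Within the data shown here, in a toxicity assay on HepG2 cells (Homo sapiens) for cytotoxicity, read by fluorescence, with a stated time of 72 h (a lower number here means a stronger inhibitor, a higher number a weaker inhibitor), compound 1 `CCCCCCCCCC(=O)N1CCC[C@H]1C(=O)N[C@H](C(=O)N[C@@H](C)C(=O)N[C@@H](CC(N)=O)C(=O)N[C@@H](C)B1O[C@@H]2C[C@@H]3C[C@@H](C3(C)C)[C@]2(C)O1)[C@H](C)O` gives 7800 nM, the only exact number so far. For compound 2 `CCCCCCc1ccc(-c2ccc(C(=O)N3CCC[C@H]3C(=O)N[C@H](C(=O)N[C@@H](C)C(=O)N[C@@H](CC(N)=O)C(=O)N[C@@H](C)B(O)O)[C@H](C)O)cc2)cc1` the assay returns only a limit, > 64000 nM. Compound 3 `C[C@H](NC(=O)[C@H](CC(N)=O)NC(=O)[C@H](C)NC(=O)[C@@H](NC(=O)[C@@H]1CCCN1)[C@H](C)O)B1O[C@@H]2C[C@@H]3C[C@@H](C3(C)C)[C@]2(C)O1` has hydrogen in place of nonylcarbonyl on an amine nitrogen in a ring. Among the measured compounds shown here, no measured pair shows this change, so the expectation starts from compound 1 at 7800 nM. An estimated step of a 5.1-fold higher number from compound 1 to compound 3 (0.71 log units; beyond the scatter) toward weaker inhibition in this assay is expected, beyond the scatter. Compound 3 is expected at about 40000 nM, within an estimated range of 15000 nM to 120000 nM.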

Compound 3, half-maximal inhibitory concentration: > 64000 nM
Compound 3 ended at the assay's limit; the forecaster's own chance of this, stated with the estimate: 55%; middle value at least 1.6-fold (0.20 log units) from the limit.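

Putting hydrogen in place of nonylcarbonyl on the amine nitrogen in the ring gives an at least 8.2-fold higher number from compound 1 to compound 3 (0.91 log units; beyond the scatter) in this assay, so the measured cytotoxicity of compound 1 depends on what this nitrogen carries. Compound 3 gives > 64000 nM, a limit of the assay and not a number. The step is therefore only a lower bound on the change: the limit of > 64000 nM in this assay, at which 2 of the 3 values shown sit.

Whether the chain or the carbonyl accounts for the step stays open. So does how a shorter chain, a longer chain or an acetyl group on this nitrogen would read.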